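Cyclopentyl for 4-Chlorophenyl: an Expected Solubility Shift

A few compounds are considered here, and "the series" means these few. Any claim that something is new, unique, unknown or untested is made for them only; others in the source may bear on it.

Compound 1 `O=C(c1ccc(Cl)cc1)N1CCN(c2nc(=O)c3cc(C(F)(F)F)cc([N+](=O)[O-])c3s2)CC1` is the starting point here. Going by the values given here, in a physicochemical assay for solubility, read by HPLC (a higher number here means a more soluble compound, a lower number a less soluble compound), compound 1 gives 5.19 ug/mL, the highest of the two numbers measured so far. Its nearest neighbour is compound 2 `CCCC(=O)N1CCN(c2nc(=O)c3cc(C(F)(F)F)cc([N+](=O)[O-])c3s2)CC1`, which in this assay gives 2.46 ug/mL. Among the compounds with values here, the single measured step between them is a 2.1-fold lower number from compound 1 to compound 2 (0.32 log units; beyond the scatter), a modest drop that goes beyond the usual scatter.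

Compound 3 `O=C(C1CCCC1)N1CCN(c2nc(=O)c3cc(C(F)(F)F)cc([N+](=O)[O-])c3s2)CC1` has not yet been measured. It differs from compound 1 in one place: cyclopentyl in place of 4-chlorophenyl on a carbonyl carbon. Within the data shown here, the one measured step bears directly on this change, since propyl and cyclopentyl are both groups of carbon only without any six-membered aromatic ring, and that step was modest in size. A step of similar size and in the same direction is therefore expected here, though the five-membered non-aromatic ring may not behave exactly like the chain. For compound 3 the expected step is a 1.9-fold lower number from compound 1 to compound 3 (0.27 log units; within the scatter). Compound 3 is thus estimated at 2.8 ug/mL, with a likely range from 1.2 ug/mL to 6.5 ug/mL.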

Compound 3, solubility: 5.34 ug/mL
For compound 3 the middle estimate is 1.9-fold (0.28 log units) below the measured one; measured number inside the range.
By their numbers in this assay, from the lowest: compound 2; then compounds 1 and 3 (each within the scatter of the next).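

In this assay the step of a 1.0-fold higher number from compound 1 to compound 3 (0.01 log units; within the scatter) shows that, on this carbonyl carbon, 4-chlorophenyl can be exchanged for cyclopentyl without a difference that stands out from the scatter, so giving up the six-membered aromatic ring and the chlorine does not by itself bring a lower number. The step of a 2.2-fold higher number from compound 2 to compound 3 (0.34 log units; beyond the scatter) goes beyond the scatter and sets the two groups without an aromatic ring apart, which shows that the lower number of compound 2 does not extend to every carbon-only group lacking that ring: here the five-membered non-aromatic ring and the propyl chain do not read alike. The data at hand offer no independent measurement that could explain why the ring and the chain differ.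

The compounds shown leave open whether a cyclobutyl or cyclohexyl ring on this carbonyl carbon would read like compound 3 or like compound 2, and where a longer chain would fall. They also leave open how a group carrying an amine or a carboxylic acid would read here, since the groups shown contain no atoms other than carbon, hydrogen and, in compound 1, chlorine.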